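Compound 3 to compound 4: 2,4-dimethylbenzyl on nitrogen

A few compounds are considered here, and "the series" means these few. Any claim that something is new, unique, unknown or untested is made for them only; others in the source may bear on it.

In an ADME assay on CCRF-CEM cells (Homo sapiens) for cytotoxicity, with a stated time of 3 days (on this read-out higher numbers stand for lower toxicity in this test and lower numbers for higher toxicity in this test), compound 3 `O=C(OC1C=CC(n2ccc(=O)[nH]c2=O)C1)c1ccccc1` gives > 250000 nM, which is a limit. Compound 1 `O=C(OC1C=CC(n2ccc(=O)n(Cc3ccccc3)c2=O)C1)c1ccccc1` gives > 25000 nM, also a limit. Compound 2 `O=C(OC1C=CC(n2ccc(=O)n(C(=O)c3ccccc3)c2=O)C1)c1ccccc1` gives >= 250000 nM, again a limit. For the measured compounds named here, the series therefore holds no exact number so far, and compound 3 stands only at its limit.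

Compound 4 `Cc1ccc(Cn2c(=O)ccn(C3C=CC(OC(=O)c4ccccc4)C3)c2=O)c(C)c1` differs from compound 3 by 2,4-dimethylbenzyl in place of hydrogen on an aromatic nitrogen. Going by the values given here, the nearest precedent is a step that the two limits leave unreadable from compound 1 to compound 3, where hydrogen replaces benzyl on an aromatic nitrogen. Also relevant are a step that the two limits leave unreadable from compound 2 to compound 3 and a step that the two limits leave unreadable from compound 1 to compound 2. None of these sizes can be read, so they give a direction at best. With a benzyl-type group in place, compound 4 is expected to resemble compound 1 more than compound 3.

The expected step is an at least 4.1-fold lower number from compound 3 to compound 4 (0.61 log units; beyond the scatter), towards lower numbers in this assay, and the result may again be only a limit. For compound 4 the estimated value is 60000 nM, with an expected range of 15000 nM to 250000 nM.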

Compound 4, half-maximal cytotoxic concentration: 31000 nM
Beside the measured number, compound 4's estimate is 1.9-fold (0.29 log units) above it; low and high end bracket the measured number.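

Compound 4 gives the series its first exact number in this assay, and it shows that a 2,4-dimethylbenzyl group on this aromatic nitrogen brings a readable move towards higher toxicity in this test, with an at least 8.0-fold lower number from compound 3 to compound 4 (0.90 log units; beyond the scatter) and an at least 8.0-fold lower number from compound 2 to compound 4 (0.90 log units; beyond the scatter). Both steps start from a limit, so each gives only a minimum size. The step between compound 1 and compound 4 cannot be read, which leaves the share of the two methyl groups unknown, and compound 1 holds only a limit: the limit of > 25000 nM in this assay, at which 1 of the 4 values shown sits.

Still open, as far as these compounds go, is how an amine or a carboxylic acid on the benzyl ring, or a longer chain between the aromatic nitrogen and that ring, would read in this assay. With a single exact number in the series, the groups on this nitrogen cannot yet be ranked.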